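Notes on methylating the side-chain amine of compound 2

A few compounds are considered here, and "the series" means these few. Any claim that something is new, unique, unknown or untested is made for them only; others in the source may bear on it.

Measured so far:
compound 1 `CCn1ccc(N2C[C@H](COC)OC2=O)c1` — 0.6 nM
compound 2 `CCn1ccc(N2C[C@H](CN)OC2=O)c1` — 130 nM

Going by the values given here, in an assay for inhibition of Amine oxidase [flavin-containing] A (Bos taurus), read by fluorescence, with a stated time of 30 min (a lower number here means a stronger inhibitor, a higher number a weaker inhibitor), compound 2 stands at the highest number of the two measured; the only other number lies far off: a 220-fold higher number from compound 1 to compound 2 (2.34 log units; beyond the scatter). Compound 3 `CCn1ccc(N2C[C@H](CNC)OC2=O)c1` carries methyl in place of hydrogen on an amine nitrogen. Among the compounds with values here, the one measured step exchanges amino for methoxy and bears only loosely on this change; no measured step adds a methyl to an amine nitrogen. A step of modest size in this assay is therefore expected, direction uncertain, estimated as a 1.6-fold lower number from compound 2 to compound 3 (0.21 log units; within the scatter). Compound 3 is expected at 80 nM, within 15 nM to 400 nM.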

Compound 3, inhibition constant: 80 nM
Compound 3: middle estimate and measured number agree at the digits printed, and the stated range covers the measured number.
By their numbers in this assay, from the lowest: compound 1; then compounds 3 and 2 (each within the scatter of the next).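

In this assay, methyl in place of hydrogen on the amine nitrogen gives a 1.6-fold lower number from compound 2 to compound 3 (0.21 log units; within the scatter) and leaves compounds 2 and 3 within the scatter of each other. Methylamino in place of methoxy still gives a 130-fold higher number from compound 1 to compound 3 (2.12 log units; beyond the scatter), so the large gap to compound 1 persists with this single methyl added. No evidence on the cause of either step is available.

Open, on these data alone, is whether dimethylamino or ethylamino at this position stays near compounds 2 and 3 or reaches the number of compound 1. Ethoxy or hydroxy in place of the methoxy of compound 1 is equally open.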